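This account rests on a few compounds, and the source may have more. Where it says the series, first, only, none or still open, it means among the compounds named here.

Measured so far in a functional assay on HL-60 cells (Homo sapiens) for cytotoxicity, read by WST assay, with a stated time of 48 h; on this read-out lower numbers stand for an effect already at smaller amounts and higher numbers for an effect only at larger amounts of compound:
Compound 1, `CCCCCCCOc1ccccc1C[C@H]1C(=O)OC[C@@H]1Cc1ccccc1`: 75000 nM
Compound 2, `O=C1OC[C@H](Cc2ccccc2)[C@H]1Cc1ccccc1F`: 72000 nM

For the measured compounds named here, compound 2 gives a number close to that of compound 1; the one measured step, a 1.0-fold lower number from compound 1 to compound 2 (0.02 log units; within the scatter), lies within the scatter, so the two cannot be told apart on these numbers. Compound 3, `O=C1OC[C@H](Cc2ccccc2)[C@H]1Cc1ccc(F)cc1`, has not yet been measured. It differs from compound 2 in one place: 4-fluorophenyl in place of 2-fluorophenyl on a saturated chain carbon bound to a saturated ring carbon. Going by the values given here, the only measured step exchanged one group for another on an aromatic carbon, whereas this change exchanges 2-fluorophenyl for 4-fluorophenyl; that measured step stayed within the scatter and gives no hint of a shift in either direction. With nothing pointing up or down, the step expected in this assay is none beyond the scatter, no change at the digits printed from compound 2 to compound 3 (within the scatter). Compound 3 is therefore estimated at 72000 nM, with a range from 30000 nM to 170000 nM.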

Compound 3, half-maximal effective concentration: 57000 nM
The estimate for compound 3 lay 1.3-fold (0.10 log units) above the measured number; the measured number falls inside the stated range.
By their numbers in this assay, from the lowest: compounds 3, 2 and 1 (each within the scatter of the next).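

In this assay, 4-fluorophenyl in place of 2-fluorophenyl on a saturated chain carbon bound to a saturated ring carbon gives a 1.3-fold lower number from compound 2 to compound 3 (0.10 log units; within the scatter), so these two groups cannot be told apart at this place. The earlier step exchanged two different groups on an aromatic carbon, whereas this one keeps the same atoms, joined differently, and adds a second step that stays within the scatter. Nothing available here explains this result.

From the compounds shown here alone, it remains open whether an amine or a carboxylic acid on this aromatic ring, in place of fluoro, would give a step beyond the scatter. Going by these compounds, it is equally open whether any change to the other phenyl group or to the shared core would do so.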